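Anilide to pyridyl amide: notes on the shared core series

The source may report more compounds than this note shows. Statements on the series, on what has been measured and on what is new or still open speak of the compounds shown alone.

Measured so far in a functional assay on the whole organism (strain Wistar) for inhibition, with Rattus norvegicus as the target, read by paw edema, with a stated time of 4 h, at a dose of 100 mg/kg; on this read-out lower numbers stand for less inhibition and higher numbers for more inhibition at the one dose given (going by the name of the read-out):
compound 1 `COc1cc2c(cc1OC)C(CC(=O)Nc1ccccc1)CC2` gives 37.5%
compound 2 `COc1cc2c(cc1OC)C(CC(=O)Nc1cccc(Cl)c1)CC2` gives 25.8%
compound 3 `COc1cc2c(cc1OC)C(CC(=O)Nc1cccc(C)c1)CC2` gives 40.6%

Compound 2 stands lowest of the three numbers in this assay. The nearest is compound 1, with a number 11.7 percentage points lower from compound 1 to compound 2 (beyond the scatter); the furthest is compound 3, with a number 14.8 percentage points higher from compound 2 to compound 3 (beyond the scatter). Between compound 1 and compound 3 the gap is a number 3.1 percentage points higher from compound 1 to compound 3 (within the scatter), so the three measured compounds span only a modest stretch.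

Compound 4 `COc1cc2c(cc1OC)C(CC(=O)Nc1ccncc1)CC2` has not yet been measured. It differs from compound 2 in one place: pyridin-4-yl in place of 3-chlorophenyl on an amide-type nitrogen.

Within the data shown here, no measured step replaces a carbon ring by a ring carrying a nitrogen, so no step bears directly on this change. The two steps that touch the same position, from compound 1 to compound 2 and from compound 2 to compound 3, show that removing the chloro, or exchanging it for methyl, moves the number upward by a modest amount. Among the measured compounds shown here, since the chloro leaves here as well, a modest rise in this assay is the best guess, with wide uncertainty because the entering pyridin-4-yl has no precedent among the measured compounds.

Compound 4 is therefore expected to give about 35%, in a range of 18% to 52%. This estimate means a step of a number 9.2 percentage points higher from compound 2 to compound 4 (within the scatter).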

Compound 4, a percentage reported as inhibition, in the whole organism at one dose (the size of the read-out at that dose, not a potency): 45.3%
Beside the measured number, compound 4's estimate is 10.3 percentage points below it; the measured number falls inside the stated range.
By their numbers in this assay, from the lowest: compound 2; then compounds 1, 3 and 4 (each within the scatter of the next).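

In this assay, among these compounds, the amide-type nitrogen accepts a ring carrying a nitrogen: exchanging 3-chlorophenyl for pyridin-4-yl gives a number 19.5 percentage points higher from compound 2 to compound 4 (beyond the scatter) and is the first step here that brings a hetero atom into this ring. Set against the rings of carbon only that lack chloro, the same group does not separate, with a number 7.8 percentage points higher from compound 1 to compound 4 (within the scatter) and a number 4.7 percentage points higher from compound 3 to compound 4 (within the scatter) as its two steps, so pyridin-4-yl stands level with phenyl and 3-methylphenyl on this read-out. Among the four groups on this nitrogen, only 3-chlorophenyl now stands apart, since compound 2 has steps beyond the scatter to each of the other three compounds.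

Open, on these data alone, is whether pyridin-3-yl, a saturated piperidin-4-yl ring or a phenyl ring bearing a carboxylic acid on this nitrogen would stay level with compound 4 or drop towards compound 2, and whether the same order would hold at other doses and times. Nothing at hand explains the numbers at this position.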